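A few compounds are considered here, and "the series" means these few. Any claim that something is new, unique, unknown or untested is made for them only; others in the source may bear on it.

Series notes. In an ADME assay on HepG2 cells (Homo sapiens) for inhibition, read by fluorescence and resazurin assay, with a stated time of 72 h (on this read-out higher numbers stand for weaker inhibition and lower numbers for stronger inhibition), compound 1 `NS(=O)(=O)c1ccc(Nc2ncc(Cl)c(Nc3ccc4nc[nH]c4c3)n2)cc1` gives 7800 nM, the lowest of the two numbers shown; compound 3 `Cc1ccc(Nc2nccc(Nc3ccc4cn[nH]c4c3)n2)cc1` gives 18000 nM, a gap beyond the scatter. Compound 2 `Cc1c2ccc(Nc3ccnc(Nc4ccc(S(N)(=O)=O)cc4)n3)cc2nn1C` gives only a limit, > 25000 nM, and not a number (the limit of > 25000 nM in this assay, at which 1 of the 3 values shown sits). Compound 4 `Cc1cnc(Nc2ccc(S(N)(=O)=O)cc2)nc1Nc1ccc2nc[nH]c2c1` is not yet measured in this assay. It differs from compound 1 by methyl in place of chloro on an aromatic carbon. Among the compounds with values here, no measured pair in the set differs in one place, so the size of this step has no measured precedent here. Expected is a small weakening, within or just beyond the scatter, as a 1.4-fold higher number from compound 1 to compound 4 (0.15 log units; within the scatter). Compound 4 is estimated at 11000 nM, with a range from 3500 nM to 30000 nM.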

Compound 4, half-maximal inhibitory concentration: 18000 nM
For compound 4 the middle estimate is 1.6-fold (0.21 log units) below the measured one; the range from low to high includes it.
By their numbers in this assay, from the lowest: compound 1; then compounds 3 and 4 (each within the scatter of the next). At a limit, above all of these: compound 2.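

The series now has its first single-place step: methyl in place of chloro on an aromatic carbon gives a 2.3-fold higher number from compound 1 to compound 4 (0.36 log units; beyond the scatter) in this assay. This position, ortho to a large group and para to a large group, therefore responds to an exchange of one heavy atom for another, with no change in hydrogen-bond donors, hydrogen-bond acceptors or net charge. No measured property in hand accounts for this step. Open, going by these compounds, is how a bare hydrogen, fluoro, methoxy or an amine would read at this position, and whether the step holds on other cores.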